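A few compounds are considered here, and "the series" means these few. Any claim that something is new, unique, unknown or untested is made for them only; others in the source may bear on it.

Working notes on the urea series.

Compound 1 `CN(C)CCCNc1nc(-c2ccc(NC(=O)Nc3ccc(Cl)cc3)cc2)nc2c(Cl)c(Cl)sc12` is taken as the starting point. In a functional assay on HT-29 cells (Homo sapiens) for cytotoxicity, read by MTT assay, with a stated time of 72 h (on this read-out lower numbers stand for stronger inhibition and higher numbers for weaker inhibition), compound 1 gives 330 nM. Compound 2 `CN(C)CCCNc1nc(-c2ccc(NC(=O)Nc3ccccc3Cl)cc2)nc2c(Cl)c(Cl)sc12` carries the change 2-chlorophenyl in place of 4-chlorophenyl on an amide-type nitrogen and in this assay compound 2 gives 820 nM. The step of a 2.5-fold higher number from compound 1 to compound 2 (0.40 log units; beyond the scatter) is therefore a loss of potency on moving the chlorine on the aryl urea.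

Compound 3 `CCN(CC)CCNc1nc(-c2ccc(NC(=O)Nc3ccc(Cl)cc3)cc2)nc2ccsc12` has a different core from compound 1; the difference between the two cores is not broken down here. In this assay compound 3 gives 150 nM, the lowest of the three numbers, and its step to compound 1 as well as to compound 2 lies beyond the scatter.

Compound 4 `CCN(CC)CCNc1nc(-c2ccc(NC(=O)Nc3ccccc3Cl)cc2)nc2ccsc12` has not yet been measured. It differs from compound 3 by 2-chlorophenyl in place of 4-chlorophenyl on an amide-type nitrogen. This is the same change as from compound 1 to compound 2, made on the core of compound 3 instead of the core of compound 1, and it occurs twice among the compounds shown. Going by the values given here, the only precedent is the single step from compound 1 to compound 2, so the expectation for compound 4 rests on one pair only and on the assumption that the change behaves alike on both cores. The step expected here is a 2.5-fold higher number from compound 3 to compound 4 (0.40 log units; beyond the scatter), because a 2.5-fold higher number from compound 1 to compound 2 (0.40 log units; beyond the scatter) went in the same direction on the related core. Compound 4 is expected to give about 380 nM in this assay, with a likely range from 200 nM to 750 nM.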

Compound 4, half-maximal inhibitory concentration: 620 nM
The estimate for compound 4 lay 1.6-fold (0.21 log units) below the measured number, and the stated range covers the measured number.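

In this assay, the same move of the chlorine on the aryl urea gives a 4.1-fold higher number from compound 3 to compound 4 (0.62 log units; beyond the scatter), so the loss of potency seen with the first pair appears again on the core of compound 3. Set beside each other, the two steps agree in direction and cannot be told apart in size: the same change on two cores in this assay, a 2.5-fold higher number (0.40 log units; beyond the scatter) from compound 1 to compound 2 and a 4.1-fold higher number (0.62 log units; beyond the scatter) from compound 3 to compound 4, 1.7-fold (0.22 log units) apart, within the scatter of two such steps. In this series, then, the change from 4-chlorophenyl to 2-chlorophenyl carried over from the core of compound 1 to the core of compound 3, but this rests on two pairs only, does not establish a rule for any other core, and does not show why the change lowers potency.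

The compounds shown leave open whether the same loss would follow with a bromine or a methyl group in place of the chlorine, or how either 2-chlorophenyl or 4-chlorophenyl would compare with a plain phenyl on the urea. Also open, going by these compounds, is whether the step would hold with a morpholine in place of the terminal amine or with a longer chain leading to it, as only the two amine chains of these four compounds are represented.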